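The source may hold more compounds than are shown below. What is called first, only, known or untested is meant among the compounds shown, and "the series" means these compounds.

Going by the values given here, compound 2 `CC(Cc1ccc(NCc2cccc(Oc3ccccc3)c2)cc1)C(=O)O` holds the only number in a functional assay on CHO cells for agonist activity at Free fatty acid receptor 1 (Homo sapiens); on this read-out lower numbers stand for an effect already at smaller amounts and higher numbers for an effect only at larger amounts of compound; in this assay compound 2 gives 100 nM. Compound 1 `O=C(O)[C@H]1C[C@@H]1c1ccc(NCc2cccc(Oc3ccccc3)c2)cc1` is the other measured compound; in this assay compound 1 gives 12.3 nM; 13.5 nM (2 entries), with the several entries of compound 1 in this assay, 12.3 nM; 13.5 nM (2 entries). Compound 3 `NC(=O)CCc1ccc(NCc2cccc(Oc3ccccc3)c2)cc1` differs from compound 2 by carbamoylmethyl in place of 1-carboxyethyl on a saturated chain carbon bound to an aromatic carbon. Among the compounds with values here, no step between measured compounds matches this change, so there is no measured guide. Carbamoylmethyl replacing 1-carboxyethyl is expected to cost much in this assay, the step of a 25-fold higher number from compound 2 to compound 3 (1.40 log units; beyond the scatter) being expected to lie well beyond the usual scatter toward weaker effect. Compound 3 is estimated at 2500 nM, within a range from 500 nM to 12000 nM.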

Compound 3, half-maximal effective concentration: 51.3 nM
Compound 3: middle estimate off by 49-fold (1.69 log units), on the high side, and the stated range ends above it.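

In this assay, the exchange of 1-carboxyethyl for carbamoylmethyl on a saturated chain carbon bound to an aromatic carbon comes out as a 1.9-fold lower number from compound 2 to compound 3 (0.29 log units; within the scatter). At this place, then, the carboxy group of compound 2 can give way to a carbamoyl group, with one heavy atom fewer, without a change that can be told from the scatter. Nothing measured here gives a reason for this. Open, going by these compounds, is whether an amine or a longer chain at this place would hold the value. Also open, on these data alone, is whether carbamoyl would be tolerated on the core of compound 1.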